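Anilide variation in the sulfonamide glycinamide series

This account rests on a few compounds, and the source may have more. Where it says the series, first, only, none or still open, it means among the compounds named here.

Compound 1 `CCCNC(=O)CN(c1cc(Cl)ccc1OC)S(=O)(=O)c1ccccc1`: in a functional assay on SH-SY5Y cells (Homo sapiens), read by MTT assay, with a stated time of 24 h (on this read-out higher numbers stand for an effect only at larger amounts of compound and lower numbers for an effect already at smaller amounts), compound 1 gives > 20000 nM, a limit of the assay.
Compound 2 `COc1ccc(Cl)cc1N(CC(=O)Nc1ccc(Cl)cc1)S(=O)(=O)c1ccccc1`: in this assay compound 2 gives > 20000 nM, a limit of the assay.

Compound 2 stands at the limit of this assay, where both values shown sit (the limit of > 20000 nM in this assay, at which 2 of the 2 values shown sit). Going by the values given here, the only measured step, a step that the two limits leave unreadable from compound 1 to compound 2, cannot be read because of the limit of > 20000 nM in this assay, at which 2 of the 2 values shown sit, so no step bears on the change now considered. Compound 3 `COc1cccc(NC(=O)CN(c2cc(Cl)ccc2OC)S(=O)(=O)c2ccccc2)c1` carries the change (3-methoxyphenyl in place of 4-chlorophenyl on an amide-type nitrogen). No step beyond the scatter is expected, a step that the limit leaves unreadable from compound 2 to compound 3. Compound 3 is estimated at 25000 nM in this assay, within 8000 nM to 80000 nM, most likely again reported only as a limit.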

Compound 3, half-maximal effective concentration: 17600 nM
The estimate for compound 3 lay 1.4-fold (0.15 log units) above the measured number; the measured number falls inside the stated range.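

In this assay, going by these compounds alone, compound 3, carrying 3-methoxyphenyl on the amide-type nitrogen, gives 17600 nM, the first value that is a number and not a limit. The change gives an at least 1.1-fold lower number from compound 2 to compound 3 (0.05 log units; that floor lies within the scatter) and an at least 1.1-fold lower number from compound 1 to compound 3 (0.05 log units; that floor lies within the scatter), so only floors can be read and neither step is shown to exceed the scatter: the limit of > 20000 nM in this assay, at which 2 of the 3 values shown sit.

Going by these compounds, the true size of both steps stays open. Also open, on these data alone, is how 3-chlorophenyl, 4-methoxyphenyl or a carboxylic acid on the anilide ring would read at this nitrogen.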